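Working notes: aryl change at the saturated ring carbon

The compounds below may be only part of what the source reports. "The series", "measured", "known", "first", "only" and "open" are said of these compounds alone.

Measured so far in a functional assay on Ehrlich cells (Mus musculus) for cytotoxicity, read by trypan blue exclusion, with a stated time of 2 h, tested at 100 ug/mL; a lower number here means a weaker effect, a higher number a stronger effect of the compound at the concentration tested:
compound 1 `N#CC1=C(N)N(c2ccc(S(N)(=O)=O)cc2)C2=C(CCCC2)C1c1ccccc1O`: 100%
compound 2 `N#CC1=C(N)N(c2ccc(S(N)(=O)=O)cc2)C2=C(CCCC2)C1c1cccc([N+](=O)[O-])c1`: 12%
compound 3 `N#CC1=C(N)N(c2ccc(S(N)(=O)=O)cc2)C2=C(CCCC2)C1c1ccc([N+](=O)[O-])cc1`: 20%

Compound 1 stands highest of the three numbers in this assay; its nearest neighbour is compound 3 and its furthest is compound 2, both beyond the scatter. The two recorded steps away from compound 1 are large drops: a number 88 percentage points lower from compound 1 to compound 2 (beyond the scatter) and a number 80 percentage points lower from compound 1 to compound 3 (beyond the scatter). Between the two nitro compounds the step is small: a number 8 percentage points higher from compound 2 to compound 3 (within the scatter).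

Compound 4 `N#CC1=C(N)N(c2ccc(S(N)(=O)=O)cc2)C2=C(CCCC2)C1c1ccccc1Cl` differs from compound 1 by chloro in place of hydroxy on an aromatic carbon; the group sits ortho to a large group. Among the measured compounds shown here, no measured step touches a chloro group, so only the two departures from the 2-hydroxyphenyl of compound 1 bear on it, and both were large in the downward direction. The estimate for compound 4 is therefore a step of a number 50 percentage points lower from compound 1 to compound 4 (beyond the scatter), expected downward, with wide uncertainty since the nitrophenyl steps need not carry over. Compound 4 is expected to give 50%, within 15% to 100%.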

Compound 4, a percentage reported as activity, at one concentration (the size of the read-out at that concentration, not a potency): 10%
The estimate for compound 4 lay 40 percentage points above the measured number; measured number outside the range, below it.
By their numbers in this assay, from the lowest: compounds 4, 2 and 3 (each within the scatter of the next); then compound 1.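

In this assay, chloro in place of hydroxy, with the group still ortho to a large group, gives a number 90 percentage points lower from compound 1 to compound 4 (beyond the scatter) as a step. This loss is as large as that seen with the nitrophenyl compounds, and the change is one of a single heavy atom on the aromatic carbon. Compound 4 also does not separate from the nitro compounds, with a number 10 percentage points lower from compound 3 to compound 4 (within the scatter) and a number 2 percentage points lower from compound 2 to compound 4 (within the scatter) as its steps, so among these four compounds the 2-chlorophenyl, 3-nitrophenyl and 4-nitrophenyl groups stay together and only the 2-hydroxyphenyl of compound 1 stands apart. Nothing at hand explains this separation.

Open, from the compounds shown here alone, is whether a methoxy or an amine in place of the hydroxy would keep the high reading of compound 1, and whether a 3-hydroxyphenyl or 4-hydroxyphenyl group would do so. All readings come from a single concentration, so the potency of these compounds also remains open.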